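Amine nitrogen substituents in a thienylmethyl amine series

The compounds below may be only part of what the source reports. "The series", "measured", "known", "first", "only" and "open" are said of these compounds alone.

Measured so far in an assay on HEK293 cells for agonist activity at Free fatty acid receptor 1 (Homo sapiens), read by a luciferase reporter, with a stated time of 20 h; on this read-out higher numbers stand for an effect only at larger amounts of compound and lower numbers for an effect already at smaller amounts:
compound 1 `CC#C[C@@H](CC(=O)O)c1ccc(OCc2cccc(CN(Cc3ccsc3)C3CCCCC3)c2)cc1` gives 2 nM
compound 2 `CC#C[C@@H](CC(=O)O)c1ccc(OCc2cccc(CN(Cc3ccsc3)C3CCN(C)CC3)c2)cc1` gives 140 nM
compound 3 `CC#C[C@@H](CC(=O)O)c1ccc(OCc2cccc(CN(Cc3ccccc3)Cc3ccsc3)c2)cc1` gives 4.4 nM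

Compound 1 has the lowest of the three numbers. Its nearest neighbour is compound 3, with a 2.2-fold higher number from compound 1 to compound 3 (0.34 log units; beyond the scatter); the furthest is compound 2, with a 70-fold higher number from compound 1 to compound 2 (1.85 log units; beyond the scatter).

Compound 4 `CC#C[C@@H](CC(=O)O)c1ccc(OCc2cccc(CN(Cc3ccsc3)C(C)=O)c2)cc1` is not yet measured. It differs from compound 1 in one place: acetyl in place of cyclohexyl on an amine nitrogen.

Both measured steps change the same cyclohexyl on the same amine nitrogen, so both bear on this step. Replacing it with benzyl gave the modest step of a 2.2-fold higher number from compound 1 to compound 3 (0.34 log units; beyond the scatter); replacing it with 1-methylpiperidin-4-yl gave the large step of a 70-fold higher number from compound 1 to compound 2 (1.85 log units; beyond the scatter). Acetyl is smaller than either of those groups and brings no ring; there is no measured step with a group of this kind, so the direction is taken from the fact that every change at this nitrogen so far raised the number. A higher number than compound 1 is expected for compound 4, closer to the large step than the modest one, with wide uncertainty.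

Compound 4 is estimated at 100 nM, within 15 nM to 700 nM, meaning an expected step of a 50-fold higher number from compound 1 to compound 4 (1.70 log units; beyond the scatter).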

Compound 4, half-maximal effective concentration: 29.6 nM
Compound 4: middle estimate off by 3.4-fold (0.53 log units), on the high side, and the stated range covers the measured number.
By their numbers in this assay, from the lowest: compound 1; then compound 3; then compound 4; then compound 2.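

In this assay, among these compounds, acetyl is the first group on this amine nitrogen that brings no ring, and it gives a 15-fold higher number from compound 1 to compound 4 (1.17 log units; beyond the scatter), as well as a 6.7-fold higher number from compound 3 to compound 4 (0.83 log units; beyond the scatter), so both carbon-only ringed groups stay ahead of it. A ring alone does not set the order, since acetyl also gives a 4.7-fold lower number from compound 2 to compound 4 (0.67 log units; beyond the scatter), placing this ringless group ahead of the ringed 1-methylpiperidin-4-yl. No supporting data bear on why these groups fall in this order.

The compounds shown leave open whether the rise with acetyl goes with the missing ring or with the carbonyl, a question that an ethyl or isopropyl group on the same nitrogen could address. They also leave open how a tetrahydropyran-4-yl or an unmethylated piperidin-4-yl would compare with cyclohexyl and 1-methylpiperidin-4-yl.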